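From 4-methylbenzyl to 3-(methoxymethyl)benzyl on compound 1

The source may report more compounds than this note shows. Statements on the series, on what has been measured and on what is new or still open speak of the compounds shown alone.

In a functional assay on L6 cells (Rattus norvegicus) for inhibition (a lower number here means a stronger inhibitor, a higher number a weaker inhibitor), compound 1 `Cc1ccc(CNC(=O)c2nn(-c3ccc(F)cc3)c(OC[C@@H](O)C[C@@H](O)CC(=O)O)c2C(C)C)cc1` gives 2110 nM and compound 2 `CC(C)c1c(C(=O)N2CCC[C@H](N3CCC4C=CC=CC4C3)C2)nn(-c2ccc(F)cc2)c1CC[C@@H](O)C[C@@H](O)CC(=O)O` gives 1720 nM, two values within the scatter of each other. Compound 3 `COCc1cccc(CNC(=O)c2nn(-c3ccc(F)cc3)c(OC[C@@H](O)C[C@@H](O)CC(=O)O)c2C(C)C)c1` keeps the core of compound 1 with one change: 3-(methoxymethyl)phenyl in place of 4-methylphenyl on a saturated chain carbon bound to an amide-type nitrogen. Going by the values given here, no measured pair tests a change at this place, so the expectation rests on the structural change alone. A shift beyond the scatter is not expected, and the estimated step is a 1.2-fold higher number from compound 1 to compound 3 (0.07 log units; within the scatter). For compound 3 the estimated value is 2500 nM, with an expected range of 800 nM to 8000 nM.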

Compound 3, half-maximal inhibitory concentration: 3600 nM
Beside the measured number, compound 3's estimate is 1.4-fold (0.16 log units) below it; measured number inside the range.
By their numbers in this assay, from the lowest: compounds 2, 1 and 3 (each within the scatter of the next, the first and the last beyond it).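

In this assay, going by these compounds alone, the swap of 4-methylphenyl for 3-(methoxymethyl)phenyl gives a 1.7-fold higher number from compound 1 to compound 3 (0.23 log units; within the scatter) and is the first reading at this place. The entering group, with one hydrogen-bond acceptor where 4-methylphenyl has none, therefore gives a number that is not separated from that of compound 1 beyond the scatter. No measured evidence on this result is available.

Since the group and its ring position change together, their contributions cannot be separated. Going by these compounds, whether an amine or a carboxylic acid in place of the methoxymethyl group would give a step beyond the scatter remains open.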